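The source may report more compounds than this note shows. Statements on the series, on what has been measured and on what is new or still open speak of the compounds shown alone.

Measured in an in vitro ADME assay on microsomes from liver (Homo sapiens) for metabolic stability; on this read-out higher numbers stand for a longer-lived compound and lower numbers for a shorter-lived compound:
Compound 1 `CC(C)CC1n2cncc2CN(CC2CC2)S1(=O)=O`: 0.917 h
Compound 2 `CC(C)CC1n2cncc2CN(C2CC2)S1(=O)=O`: > 6.75 h

Compound 2 is reported only as a limit: the limit of > 6.75 h in this assay, at which 1 of the 2 values shown sits. In compound 3 `CC(C)CC1n2cncc2CN(Cc2ccccc2)S1(=O)=O`, benzyl takes the place of cyclopropyl on a sulfonamide nitrogen in a ring: benzyl in place of cyclopropyl on a sulfonamide nitrogen in a ring. Going by the values given here, the one measured step that bears on this is an at least 7.3-fold higher number from compound 1 to compound 2 (0.86 log units; beyond the scatter), for cyclopropyl in place of cyclopropylmethyl. Benzyl is closer in kind to that cyclopropylmethyl, so a lower number in this assay, beyond the scatter, is expected, near compound 1 at 0.917 h. The expected change is an at least 7.5-fold lower number from compound 2 to compound 3 (0.87 log units; beyond the scatter). Compound 3 is estimated at 0.9 h, within an expected range of 0.3 h to 2.7 h.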

Compound 3, half-life: 0.05 h
Compound 3: middle estimate off by 18-fold (1.26 log units), on the high side, and the stated range ends above it.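

Not every group carrying a saturated chain carbon on the sulfonamide nitrogen in a ring behaves alike: in this assay there is an 18-fold lower number from compound 1 to compound 3 (1.26 log units; beyond the scatter), for phenyl in place of cyclopropyl on that carbon. Against cyclopropyl directly on the nitrogen, benzyl gives an at least 130-fold lower number from compound 2 to compound 3 (2.13 log units; beyond the scatter). Compound 2 is reported only as a limit, so that step is a bound and not a measured size: the limit of > 6.75 h in this assay, at which 1 of the 3 values shown sits.

Still open, from the compounds shown here alone, is how a small group without a ring, such as methyl or isopropyl, would behave on this nitrogen. Also open, going by these compounds, is whether phenyl set directly on the nitrogen would behave like benzyl or like cyclopropyl.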